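The source may hold more compounds than are shown below. What is called first, only, known or untested is meant among the compounds shown, and "the series" means these compounds.

Measured compounds in an assay on HEK293 cells for inhibition of solute carrier family 22 member 12 (Homo sapiens), read by scintillation counting, with stated times of 30 min and 15 min; a lower number here means a stronger inhibitor, a higher number a weaker inhibitor:
- compound 1, `CN(c1cnccc1SCCCC(=O)O)c1ccc(C#N)c2ccccc12`: 2580 nM
- compound 2, `N#Cc1ccc(Oc2cnccc2SCCCC(=O)O)c2ccccc12`: 1230 nM
- compound 3, `N#Cc1ccc(Oc2cnccc2SCCCCCCC(=O)O)c2ccccc12`: 3780 nM

Of the three numbers in this assay, compound 1 gives the second highest. Compound 2 gives a lower number than compound 1, and that gap lies beyond the scatter. Compound 3 gives a number within the scatter of compound 1, so no order between compound 1 and compound 3 can be read from this assay.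

Compound 4, `CN(c1cnccc1SCCCCCCC(=O)O)c1ccc(C#N)c2ccccc12`, has not yet been measured. It differs from compound 1 in one place: 3-carboxypropyl in place of carboxy on a saturated chain carbon, three bonds along the chain from a sulfur

The same change has been measured once in this set, on the shared core carrying the other side group: a 3.1-fold higher number from compound 2 to compound 3 (0.49 log units; beyond the scatter). That step was modest but beyond the scatter, the longer chain giving the weaker inhibitor. Nothing in the measured compounds shows that the side group on the core alters how this chain change reads, so the step from compound 1 to compound 4 is expected to run in the same direction and at about the same size: a 3.1-fold higher number from compound 1 to compound 4 (0.49 log units; beyond the scatter), an expected rise in the number.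

On this basis compound 4 is estimated in this assay at 8000 nM, with a likely range from 3500 nM to 18000 nM.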

Compound 4, half-maximal inhibitory concentration: 4640 nM
For compound 4 the middle estimate is 1.7-fold (0.24 log units) above the measured one; the measured number falls inside the stated range.
By their numbers in this assay, from the lowest: compound 2; then compounds 1, 3 and 4 (each within the scatter of the next).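

On the core of compound 1, the change to 3-carboxypropyl in place of carboxy, on a saturated chain carbon three bonds along the chain from a sulfur, now has its own reading in this assay (a 1.8-fold higher number from compound 1 to compound 4 (0.25 log units; within the scatter)), so no order between these two compounds can be read. The earlier reading (a 3.1-fold higher number from compound 2 to compound 3 (0.49 log units; beyond the scatter)) rested on one core alone and lay beyond the scatter, which left open whether the chain change would also clear the scatter on the second core; on that core it does not. Even so, the two readings cannot be told apart, and these compounds give no sign that the side group on the core alters the chain change: the same change on two cores in this assay, a 3.1-fold higher number (0.49 log units; beyond the scatter) from compound 2 to compound 3 and a 1.8-fold higher number (0.25 log units; within the scatter) from compound 1 to compound 4, 1.7-fold (0.23 log units) apart, within the scatter of two such steps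

Two chain lengths on two cores give no profile across chain length, so a chain of intermediate length, such as 2-carboxyethyl in place of carboxy, or a longer chain could read differently from both ends shown here. Also open, going by these compounds, is how an amide or a tetrazole in place of the carboxylic acid would read at the end of either chain.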